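A Furan-2-yl Ketone Swapped for 3-Aminophenyl

The source may hold more compounds than are shown below. What is called first, only, known or untested is meant among the compounds shown, and "the series" means these compounds.

Measured so far:
Compound 1 `O=C(/C=C/c1ccc2c(c1)B(O)OC2)c1ccco1` gives > 10 ug/mL in an ADME assay on L929 cells (Mus musculus) for cytotoxicity, read by resazurin assay, with a stated time of 72 h; on this read-out higher numbers stand for weaker inhibition and lower numbers for stronger inhibition.
Compound 2 `COc1cccc(C(=O)/C=C/c2ccccc2)c1` gives 5.7 ug/mL in this assay.
Compound 3 `COc1ccc(C(=O)/C=C/c2ccc3c(c2)B(O)OC3)c(OC)c1` gives 7.87 ug/mL in this assay.

The value of compound 1 is a limit of the measurement, not a number: it sits at the limit of > 10 ug/mL in this assay, at which 1 of the 3 values shown sits, so its true position is known only as a range. Compound 4 `Nc1cccc(C(=O)/C=C/c2ccc3c(c2)B(O)OC3)c1` differs from compound 1 by 3-aminophenyl in place of furan-2-yl on a carbonyl carbon. Among the measured compounds shown here, no measured pair shares this change. Compounds 2 and 3, which carry a six-membered carbon ring on the carbonyl, both give numbers inside the measurable range. Compound 4 is therefore estimated at 8 ug/mL, with a range from 3 ug/mL to 20 ug/mL. This corresponds to an expected step of an at least 1.2-fold lower number from compound 1 to compound 4 (0.09 log units; that floor lies within the scatter) in this assay, toward stronger inhibition, though a limit again remains possible.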

Compound 4, half-maximal inhibitory concentration: 10 ug/mL
For compound 4 the middle estimate is 1.3-fold (0.10 log units) below the measured one; the range from low to high includes it.
By their numbers in this assay, from the lowest: compounds 2, 3 and 4 (each within the scatter of the next).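

With 3-aminophenyl in place of furan-2-yl on a carbonyl carbon, this assay shows a number no higher from compound 1 to compound 4 (the limit leaves the size open). Compound 1 carries a limit rather than a number, so the size of this step cannot be read: the limit of > 10 ug/mL in this assay, at which 1 of the 4 values shown sits. Compound 4 gives a number, 10 ug/mL, so this change provides a measured value on the shared core.

From the compounds shown here alone, how far compound 1 truly lies from compound 4 stays open. So does the effect of a carboxylic acid or a hydroxyl group in place of the amine of 3-aminophenyl.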